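The source may hold more compounds than are shown below. What is called first, only, known or untested is meant among the compounds shown, and "the series" means these compounds.

Measured so far:
Compound 1, `COc1cccc(/C=C2\CCC/C(=C\c3cccc(O)c3)C2=O)c1OC`, gives 8800 nM.
Compound 2, `COc1cccc(/C=C2\CCC/C(=C\c3ccc(O)cc3)C2=O)c1OC`, reaches only a limit, > 20000 nM.
Compound 3, `COc1ccc(/C=C2\CCC/C(=C\c3cccc(O)c3)C2=O)cc1OC`, gives 2900 nM.

In a functional assay on MCF7 cells (Homo sapiens) for cytotoxicity, read by MTT assay, with a stated time of 72 h (on this read-out lower numbers stand for stronger inhibition and higher numbers for weaker inhibition), compound 1 gives 8800 nM. For compound 2 this assay reports only a limit, > 20000 nM. Compound 3 gives 2900 nM in this assay, the lowest of the two numbers. The difference between the core of compound 1 and that of compound 3 is not broken down here. The change from compound 1 to compound 2 is 4-hydroxyphenyl in place of 3-hydroxyphenyl on a double-bonded chain carbon bound to a double-bonded ring carbon, and it gave an at least 2.2-fold higher number from compound 1 to compound 2 (0.35 log units; beyond the scatter); its full size is open because of the limit of > 20000 nM in this assay, at which 1 of the 3 values shown sits.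

Compound 4, `COc1ccc(/C=C2\CCC/C(=C\c3ccc(O)cc3)C2=O)cc1OC`, carries the same change relative to compound 3: 4-hydroxyphenyl in place of 3-hydroxyphenyl on a double-bonded chain carbon bound to a double-bonded ring carbon. For compound 4 a step of about a 3.4-fold higher number from compound 3 to compound 4 (0.54 log units; beyond the scatter) is expected. This expectation rests on the measured step of an at least 2.2-fold higher number from compound 1 to compound 2 (0.35 log units; beyond the scatter). Compound 4 is therefore estimated at 10000 nM, between 4000 nM and 30000 nM.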

Compound 4, half-maximal inhibitory concentration: 17000 nM
The estimate for compound 4 lay 1.7-fold (0.23 log units) below the measured number; the measured number falls inside the stated range.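

In this assay, 4-hydroxyphenyl in place of 3-hydroxyphenyl again raised the number on the second core, a 5.9-fold higher number from compound 3 to compound 4 (0.77 log units; beyond the scatter). The direction of the change therefore carried over between the two cores shown: the same change on two cores in this assay, an at least 2.2-fold higher number (0.35 log units; beyond the scatter) from compound 1 to compound 2 and a 5.9-fold higher number (0.77 log units; beyond the scatter) from compound 3 to compound 4; the limit leaves it open whether they differ Whether its size carried over as well is not shown, since compound 2 stands at a limit: the limit of > 20000 nM in this assay, at which 1 of the 4 values shown sits.

The compounds shown leave open how an amine or a carboxylic acid in place of the hydroxyl would read in this assay. They also leave open whether the same step would appear on any core beyond these two.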